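A few compounds are considered here, and "the series" means these few. Any claim that something is new, unique, unknown or untested is made for them only; others in the source may bear on it.

Three compounds share one core and differ only in the aryl group attached to the amide nitrogen. Compound 1 `O=C(CN1CCN(c2cc3c(cc2F)c(=O)c(C(=O)O)cn3C2CC2)CC1)Nc1ccc(Cl)cc1` carries a 4-chlorophenyl there, and in a functional assay on A549 cells (Homo sapiens) for antiproliferative activity, read by BrdU incorporation, with a stated time of 24 h (a lower number here means a stronger inhibitor, a higher number a weaker inhibitor), compound 1 gives 14800 nM. Compound 2 `COc1ccccc1NC(=O)CN1CCN(c2cc3c(cc2F)c(=O)c(C(=O)O)cn3C2CC2)CC1` carries a 2-methoxyphenyl, and for compound 2 the assay reports only a limit, > 100000 nM. Compound 3 `COc1ccc(NC(=O)CN2CCN(c3cc4c(cc3F)c(=O)c(C(=O)O)cn4C3CC3)CC2)cc1` carries a 4-methoxyphenyl, and compound 3 gives 24800 nM. Compound 3 stands alongside compound 1, since a 1.7-fold higher number from compound 1 to compound 3 (0.22 log units; within the scatter). Against compound 2 it is set apart, since an at least 4.0-fold lower number from compound 2 to compound 3 (0.60 log units; beyond the scatter), and likewise an at least 6.7-fold higher number from compound 1 to compound 2 (0.82 log units; beyond the scatter).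

Compound 4 `COc1cc(NC(=O)CN2CCN(c3cc4c(cc3F)c(=O)c(C(=O)O)cn4C3CC3)CC2)cc(OC)c1OC` is not yet measured. It arises from compound 3 by the change (3,4,5-trimethoxyphenyl in place of 4-methoxyphenyl on an amide-type nitrogen). Among the compounds with values here, two measured steps bear on it. The exchange of chloro for methoxy, a 1.7-fold higher number from compound 1 to compound 3 (0.22 log units; within the scatter), shows that a single change at that position leaves the number essentially where it was. The move of a methoxy to another position, an at least 4.0-fold lower number from compound 2 to compound 3 (0.60 log units; beyond the scatter), shows that placing the group elsewhere on the ring can matter. Adding two further methoxy groups is therefore expected to shift the number only modestly, if at all, toward a weaker inhibitor, a 1.2-fold higher number from compound 3 to compound 4 (0.08 log units; within the scatter). Compound 4 is thus estimated at 30000 nM, within a range from 10000 nM to 100000 nM.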

Compound 4, half-maximal inhibitory concentration: > 100000 nM
Compound 4: a limit, no number (the forecaster's own chance of this, stated with the estimate: 25%); middle value at least 3.3-fold (0.52 log units) from the limit.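

In this assay, within the data shown here, the earlier compounds showed that 4-chlorophenyl and 4-methoxyphenyl on the amide nitrogen read alike, and that only the 2-methoxyphenyl group stood apart. Compound 4 shows that the ring can also lose activity by gaining groups, not only by having a methoxy moved: going from 4-methoxyphenyl to 3,4,5-trimethoxyphenyl gives an at least 4.0-fold higher number from compound 3 to compound 4 (0.60 log units; beyond the scatter), and the comparison with 4-chlorophenyl gives an at least 6.7-fold higher number from compound 1 to compound 4 (0.82 log units; beyond the scatter). The true size of these steps and the step between compound 2 and compound 4 cannot be read, because both of these compounds stand at a limit, not at a number: the limit of > 100000 nM in this assay, at which 2 of the 4 values shown sit.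

The compounds shown leave open whether one added methoxy already brings this loss or whether it takes both, which a dimethoxyphenyl group on the same amide nitrogen could help to settle. They also leave open how the aryl ring would respond to an amine or a carboxylic acid in place of methoxy, or how activity would respond to a longer chain between the amide and the piperazine-bearing core.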